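Lactone series: fluoro for trifluoromethyl on the pendant ring

The source may hold more compounds than are shown below. What is called first, only, known or untested is meant among the compounds shown, and "the series" means these compounds.

The shared core carries two benzyl groups on the lactone ring; the series varies a substituent on one of them. Compound 1 `O=C1OC[C@H](Cc2ccccc2)[C@H]1Cc1ccccc1C(F)(F)F` gives 37000 nM in a functional assay on HL-60 cells (Homo sapiens) for cytotoxicity, read by WST assay, with a stated time of 48 h; on this read-out higher numbers stand for an effect only at larger amounts of compound and lower numbers for an effect already at smaller amounts. Compound 2 `O=C1OC[C@H](Cc2ccccc2)[C@H]1Cc1ccccc1F` gives 72000 nM in this assay. The change from compound 1 to compound 2 is fluoro in place of trifluoromethyl on an aromatic carbon, and it made a step of a 1.9-fold higher number from compound 1 to compound 2 (0.29 log units; within the scatter). Compound 3 `O=C1OC[C@H](Cc2ccccc2)[C@H]1Cc1cccc(C(F)(F)F)c1` gives 34000 nM in this assay; the difference between the core of compound 3 and the core of compound 1 is not broken down here. The values of compound 3 and compound 1 lie within the scatter of each other, while the value of compound 2 stands higher than that of compound 3 by a gap beyond the scatter.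

Compound 4 `O=C1OC[C@H](Cc2ccccc2)[C@H]1Cc1cccc(F)c1` has not yet been measured in this assay. It differs from compound 3 by fluoro in place of trifluoromethyl on an aromatic carbon. This is the same kind of change as that from compound 1 to compound 2, but not the same: there the place was ortho to a large group, here it is meta to a large group. Within the data shown here, with only one earlier example, the expectation rests on compound 1 and compound 2, whose step a 1.9-fold higher number from compound 1 to compound 2 (0.29 log units; within the scatter) was within the scatter. A step of about a 1.8-fold higher number from compound 3 to compound 4 (0.25 log units; within the scatter) is therefore expected from compound 3 to compound 4 in this assay. For compound 4 the value in this assay is estimated at 60000 nM, with a plausible range from 30000 nM to 120000 nM.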

Compound 4, half-maximal effective concentration: 75000 nM
Compound 4: middle estimate off by 1.3-fold (0.10 log units), on the low side; measured number inside the range.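

In this assay, fluoro in place of trifluoromethyl on an aromatic carbon gives a 2.2-fold higher number from compound 3 to compound 4 (0.34 log units; beyond the scatter), and this step matches the one seen on the other core: the same change on two cores in this assay, a 1.9-fold higher number (0.29 log units; within the scatter) from compound 1 to compound 2 and a 2.2-fold higher number (0.34 log units; beyond the scatter) from compound 3 to compound 4, 1.1-fold (0.05 log units) apart, within the scatter of two such steps. The two fluoro compounds also show no separation, since 3-fluorophenyl in place of 2-fluorophenyl gives a 1.0-fold higher number from compound 2 to compound 4 (0.02 log units; within the scatter). So the change carries over with a similar size between these two cores in this assay, although only the step on compound 3 is printed as beyond the scatter; two examples show neither that it will hold on a further core nor why the number moves, and the cytotoxicity values all stay in a narrow, weak band.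

The four compounds carry only trifluoromethyl or fluoro on the varied benzyl group, which leaves open how a chloro, methoxy, nitrile or amine would read there. The second benzyl group and the lactone stay the same throughout, so a substituent on that benzyl group, or a carboxylic acid or amide in place of the lactone, also remains an open question for the series.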